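A few compounds are considered here, and "the series" means these few. Any claim that something is new, unique, unknown or untested is made for them only; others in the source may bear on it.

Compound 2 `O=C1N=C(C2C(=O)c3ccccc3C2=O)CC(c2ccc([N+](=O)[O-])cc2)N1` is measured in a functional assay on the whole organism for inhibition, with Mus musculus as the target, in the writhing test, with a stated time of 15 min, at a dose of 10 mg/kg (on this read-out lower numbers stand for less inhibition and higher numbers for more inhibition at the one dose given (going by the name of the read-out)), and gives 38%. Its one measured companion, compound 1 `O=C1N=C(C2C(=O)c3ccccc3C2=O)CC(c2ccccc2)N1`, gives 31% in this assay; the step of a number 7 percentage points higher from compound 1 to compound 2 (within the scatter) stays inside the usual scatter. Compound 3 `O=C1N=C(C2C(=O)c3ccccc3C2=O)CC(c2ccco2)N1` differs from compound 2 by furan-2-yl in place of 4-nitrophenyl on a saturated ring carbon. For the measured compounds named here, no measured step exchanges one aromatic ring for another on this carbon, so the single known step offers no direction for this change. The expectation is therefore no shift beyond the scatter, and compound 3 is estimated at 32%, between 18% and 46%, a step of a number 6 percentage points lower from compound 2 to compound 3 (within the scatter).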

Compound 3, a percentage reported as inhibition, in the whole organism at one dose (the size of the read-out at that dose, not a potency): 25%
The estimate for compound 3 lay 7 percentage points above the measured number; measured number inside the range.
By their numbers in this assay, from the lowest: compounds 3, 1 and 2 (each within the scatter of the next, the first and the last beyond it).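

For the compounds shown here, exchanging 4-nitrophenyl for furan-2-yl on this saturated ring carbon gives a number 13 percentage points lower from compound 2 to compound 3 (beyond the scatter), the first step in this small set to pass the scatter, so the choice of aromatic ring here can register in this assay. Exchanging phenyl for furan-2-yl gives a number 6 percentage points lower from compound 1 to compound 3 (within the scatter), so furan-2-yl stands apart from 4-nitrophenyl but not from phenyl. Nothing available explains this difference. Still open, on these data alone, is how an amine on the phenyl ring of compound 1, or a cyclohexyl group in place of that ring, would read, and whether any group on this carbon can lift the number clearly above that of compound 2.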